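The source may hold more compounds than are shown below. What is called first, only, known or untested is meant among the compounds shown, and "the series" means these compounds.

Compound 3 `CCCCC(Sc1ccc(OCCCOc2ccc3ncccc3c2)cc1)C(=O)O` carries a quinolin-6-yl group at one end and a free carboxylic acid at the other. In an assay on isolated protein for inhibition of Polyunsaturated fatty acid 5-lipoxygenase (Homo sapiens), read by HPLC, with a stated time of 15 min, in the presence of a further agent that is not named here (on this read-out higher numbers stand for weaker inhibition and lower numbers for stronger inhibition), compound 3 reaches only the limit of > 10000 nM. Its two neighbours give numbers. Compound 1 `CCCCC(Sc1ccc(OCCCOc2cccc(C)c2)cc1)C(=O)O`, which has 3-methylphenyl in place of the quinolin-6-yl, gives 4800 nM in this assay. Compound 2 `CCCCC(Sc1ccc(OCCCOc2ccc3ncccc3c2)cc1)C(=O)OCC`, carrying an ethyl group on the oxygen next to the carbonyl, gives 800 nM in this assay. The step of an at least 2.0-fold higher number from compound 1 to compound 3 (0.31 log units; beyond the scatter) shows that swapping 3-methylphenyl for quinolin-6-yl weakened inhibition, and the step of an at least 12-fold higher number from compound 2 to compound 3 (1.09 log units; beyond the scatter) shows that the free acid is weaker than its ester. Compound 4 `CCCCC(Sc1ccc(OCCCOc2cccc(C(C)C)c2)cc1)C(=O)O` keeps the free acid of compound 3 but differs in one place: 3-isopropylphenyl in place of quinolin-6-yl on an oxygen on a saturated carbon. Among the compounds with values here, of the measured steps, only the one from compound 1 to compound 3 concerns this position, and compound 4 runs it in reverse. Compound 4 is therefore expected to show a fall in the number, a step of an at least 2.8-fold lower number from compound 3 to compound 4 (0.45 log units; beyond the scatter), because compound 1 gave 4800 nM with a closely related alkylphenyl group. Compound 4 is estimated at 3500 nM, with a likely range from 1200 nM to 10000 nM.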

Compound 4, half-maximal inhibitory concentration: 1400 nM
Beside the measured number, compound 4's estimate is 2.5-fold (0.40 log units) above it; measured number inside the range.
By their numbers in this assay, from the lowest: compounds 2 and 4 (each within the scatter of the next); then compound 1. At a limit, above all of these: compound 3.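

Replacing quinolin-6-yl with 3-isopropylphenyl gives an at least 7.1-fold lower number from compound 3 to compound 4 (0.85 log units; beyond the scatter) in this assay. The earlier compounds shown here could not show that the alkyl group on the phenyl ring itself matters: isopropyl in place of methyl on an aromatic carbon gives a 3.4-fold lower number from compound 1 to compound 4 (0.54 log units; beyond the scatter). Compound 3 stands only at a limit, so the full size of its step to compound 4 stays unknown: the limit of > 10000 nM in this assay, at which 1 of the 4 values shown sits.

The compounds shown leave open how another group on that aromatic carbon, such as tert-butyl or an amine, would change the number. They also leave open whether an ethyl group on the oxygen next to a carbonyl group would change compound 4 as it separates compound 2 from compound 3.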